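This account rests on a few compounds, and the source may have more. Where it says the series, first, only, none or still open, it means among the compounds named here.

Compound 1 `N#Cc1c(-c2ccccc2Cl)c(C#N)c(=O)n(/N=C/c2cn(-c3ccccc3)nc2-c2ccccc2)c1N` was tested in an ADME assay on HeLa cells (Homo sapiens) for cytotoxicity, read by MTT assay; a lower number here means a stronger inhibitor, a higher number a weaker inhibitor. In this assay compound 1 gives > 200 ug/mL, which is a limit of the assay rather than a measured number. Two close relatives of compound 1 share the same core and differ from it only in the aromatic ring hanging from that core. Compound 2 `N#Cc1c(-c2cccc(Cl)c2)c(C#N)c(=O)n(/N=C/c2cn(-c3ccccc3)nc2-c2ccccc2)c1N` gives > 200 ug/mL in this assay, again a limit. Compound 3 `COc1ccc(-c2c(C#N)c(N)n(/N=C/c3cn(-c4ccccc4)nc3-c3ccccc3)c(=O)c2C#N)cc1` gives > 200 ug/mL in this assay, also a limit. The steps a step that the two limits leave unreadable from compound 1 to compound 2, a step that the two limits leave unreadable from compound 1 to compound 3 and a step that the two limits leave unreadable from compound 2 to compound 3 therefore carry no readable size, since (the limit of > 200 ug/mL in this assay, at which 3 of the 3 values shown sit).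

Compound 4 `N#Cc1c(-c2ccccc2[N+](=O)[O-])c(C#N)c(=O)n(/N=C/c2cn(-c3ccccc3)nc2-c2ccccc2)c1N` has not yet been measured. It differs from compound 1 in one place: nitro in place of chloro on an aromatic carbon.

Among the measured compounds shown here, none of the measured steps involves nitro in place of chloro, and all three are unreadable in size, so they give no direction for this change. For the measured compounds named here, with every value so far sitting at the same limit, the natural expectation is that compound 4 behaves like its relatives. The expected size of the step that the limit leaves unreadable from compound 1 to compound 4 is nothing beyond the scatter. Compound 4 is estimated at 250 ug/mL, with a range from 120 ug/mL to 600 ug/mL, and the assay will most likely again report only its limit.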

Compound 4, half-maximal inhibitory concentration: > 200 ug/mL
Compound 4 gave a limit, no number (the forecaster's own chance of this, stated with the estimate: 85%); the middle value is on the limit's open side.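

In this assay compound 4 gives > 200 ug/mL, which is a limit and not a measured number. Its steps to compound 1, compound 2 and compound 3 therefore cannot be read: the limit of > 200 ug/mL in this assay, at which 4 of the 4 values shown sit. The compounds shown leave open whether any change to this aromatic ring would give a measurable value in this assay.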